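The source may hold more compounds than are shown below. What is called first, only, known or untested is meant among the compounds shown, and "the series" means these compounds.

In an ADME assay on MT4 cells (Homo sapiens) for cytotoxicity (a higher number here means that more compound is tolerated, a lower number that less compound is tolerated), compound 1 (`Cc1ccc(NC(=S)Nc2cccc(C(F)(F)F)c2)cc1Cl`) gives 20000 nM and compound 2 (`CCCCc1ccc(NC(=S)Nc2cccc(C(F)(F)F)c2)c(C)c1`) gives 43000 nM as measured numbers. Compound 3 (`CCNC(=S)Nc1cccc(C(F)(F)F)c1`) gives > 100000 nM as a limit of the assay and not a number. Compound 4 (`CSCCCNC(=S)Nc1cccc(C(F)(F)F)c1`) follows from compound 3 through (methylsulfanyl)methyl in place of hydrogen on a saturated chain carbon, two bonds along the chain from an amide-type nitrogen in which ethyl becomes 3-(methylsulfanyl)propyl. No measured step sizes this change. Going by the values given here, a modest move toward a lower number is expected in this assay resting on compound 1 at 20000 nM and compound 2 at 43000 nM as the only numbers in hand. The estimated change is an at least 1.6-fold lower number from compound 3 to compound 4 (0.22 log units; that floor lies within the scatter) in size. For compound 4 the estimated value is 60000 nM within an expected range of 25000 nM to 100000 nM and a reading at the assay limit remains possible.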

Compound 4, half-maximal cytotoxic concentration: 43000 nM
The estimate for compound 4 lay 1.4-fold (0.14 log units) above the measured number; measured number inside the range.
By their numbers in this assay, from the lowest: compound 1; then compounds 2 and 4 (each within the scatter of the next). At a limit, above all of these: compound 3.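

Going by these compounds alone, replacing ethyl with 3-(methylsulfanyl)propyl gives an at least 2.3-fold lower number from compound 3 to compound 4 (0.36 log units; beyond the scatter) in this assay, the first measured step at this saturated chain position. A change on this chain alone, with the rest of compound 3 kept, is therefore enough to bring a measured number into range. Compound 3 holds a limit and not a number, so the size of the step stays a floor: the limit of > 100000 nM in this assay, at which 1 of the 4 values shown sits.

Open, from the compounds shown here alone, is whether the step follows the sulfur or the chain length, which a plain pentyl chain or a 3-methoxypropyl group at this place could separate. Also open, going by these compounds, is how an amine or a carboxylic acid on this chain would read.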